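The source may report more compounds than this note shows. Statements on the series, on what has been measured and on what is new or still open speak of the compounds shown alone.

Of the compounds shown here, three that share one core have been tested in an ADME assay on Vero cells (Chlorocebus sabaeus) for cytotoxicity; on this read-out lower numbers stand for higher toxicity in this test and higher numbers for lower toxicity in this test. Compound 1 `COc1ccc(-c2nc3cc(C(F)(F)F)ccc3[nH]2)c(OC)c1OC` gives 70000 nM in this assay. Compound 3 `CCC(=O)Nc1ccc(-c2nc3cc(C(F)(F)F)ccc3[nH]2)cc1` reaches only a limit of this assay, reported as > 100000 nM, so no number is known for it. Compound 2 `CN1CCN(CC(=O)Nc2ccc(-c3nc4cc(C(F)(F)F)ccc4n3C)cc2)CC1` likewise shows only a limit in this assay, > 100000 nM. Going by the values given here, compound 2 thus stands at the limit of > 100000 nM in this assay, at which 2 of the 3 values shown sit, and no step between measured compounds that differ in a single place is available to guide the next move; the one compound with a number, compound 1, sits not far from that limit.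

Compound 4 `Cn1c(-c2ccc(NC(=O)CN3CCN(c4ccccc4)CC3)cc2)nc2cc(C(F)(F)F)ccc21` differs from compound 2 by phenyl in place of methyl on an amine nitrogen in a ring. Among the compounds with values here, with no comparable step recorded, the expected step is modest: the change an at least 1.6-fold lower number from compound 2 to compound 4 (0.22 log units; that floor lies within the scatter) is expected to shift toward higher toxicity by little more than the usual scatter, if at all. Compound 4 is therefore estimated at 60000 nM in this assay, with a range from 25000 nM to 150000 nM, and a fair chance remains that this assay again returns only a limit for compound 4.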

Compound 4, half-maximal cytotoxic concentration: 30000 nM
Estimate against measurement, compound 4: 2.0-fold (0.30 log units) above, within the range that was stated.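

In this assay the change from methyl to phenyl on an amine nitrogen in a ring gives an at least 3.3-fold lower number from compound 2 to compound 4 (0.52 log units; beyond the scatter) and so shifts the read-out toward higher toxicity in this test. Going by these compounds alone, this is the first step in the set that can be read, and it shows that this place, three ring bonds from the ring nitrogen, is not silent: going from 4-methylpiperazin-1-yl to 4-phenylpiperazin-1-yl brings the read-out off the limit and onto a measured number. Going by these compounds, the true size of the step remains unknown, and the figure is only a floor, because one end of the step is not a number: the limit of > 100000 nM in this assay, at which 2 of the 4 values shown sit.

The compounds shown leave open whether the shift follows the aromatic ring itself or simply the larger group on that nitrogen, a question that a cyclohexyl ring or a benzyl group in the same place would help to separate. They also leave open whether phenyl at this nitrogen does the same on a core that lacks the methyl carried by compound 2 and compound 4.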